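From chloro to hydroxy: a small step expected

A few compounds are considered here, and "the series" means these few. Any claim that something is new, unique, unknown or untested is made for them only; others in the source may bear on it.

Three compounds built on a shared core, and differing in one group, have been measured in an ADME assay on HEK293 cells (Homo sapiens) for cytotoxicity, read by resazurin assay, with a stated time of 48 h (a higher number here means that more compound is tolerated, a lower number that less compound is tolerated), so far. For compound 1 (`O=S(=O)(Nc1ccc2oc(-c3ccccc3)nc2c1)c1cccc(C(F)(F)F)c1`) the reading of > 100000 nM is a limit of the assay and not a number. Compound 2 (`O=S(=O)(Nc1ccc2oc(-c3ccccc3)nc2c1)c1cccc(F)c1`) gives 68000 nM and compound 3 (`O=S(=O)(Nc1ccc2oc(-c3ccccc3)nc2c1)c1cccc(Cl)c1`) gives 70000 nM in the same test. These two therefore stand level, as the direct comparison shows (a 1.0-fold higher number from compound 2 to compound 3 (0.01 log units; within the scatter)).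

Compound 4 (`O=S(=O)(Nc1ccc2oc(-c3ccccc3)nc2c1)c1cccc(O)c1`) has hydroxy in place of chloro on an aromatic carbon, so 3-chlorophenyl becomes 3-hydroxyphenyl.

Going by the values given here, no measured compound carries hydroxy, so the other steps guide only loosely. Two more steps change this same group (an at least 1.4-fold lower number from compound 1 to compound 2 (0.16 log units; that floor lies within the scatter); an at least 1.4-fold lower number from compound 1 to compound 3 (0.15 log units; that floor lies within the scatter)). Both start from the limit of compound 1, so each gives only a floor, and that floor lies within the scatter. Together with the level pair, they give no firm sign of a large swing when this group changes.

No step beyond the scatter is therefore expected in this assay and no clear direction can be called (a 1.1-fold lower number from compound 3 to compound 4 (0.03 log units; within the scatter)). Compound 4 is estimated at 65000 nM (expected range 30000 nM to 100000 nM).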

Compound 4, half-maximal cytotoxic concentration: > 100000 nM
Compound 4: only a limit was reported (the forecaster's own chance of this, stated with the estimate: 20%); middle value at least 1.5-fold (0.18 log units) from the limit.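

In this assay, putting hydroxy at this position gives an at least 1.4-fold higher number from compound 3 to compound 4 (0.15 log units; that floor lies within the scatter), and starting from fluoro it gives an at least 1.4-fold higher number from compound 2 to compound 4 (0.16 log units; that floor lies within the scatter); these are only floors, so the true size of each step is not known. The position therefore tolerates a group with a hydrogen-bond donor and a hydrogen-bond acceptor without any sign of a lower number, and hydroxy in compound 4 now sits with trifluoromethyl in compound 1 at the top of the range, while fluoro in compound 2 and chloro in compound 3 still give readable numbers. The step between compound 1 and compound 4 cannot be read, and the other two steps stop at floors, because both compounds reach a reading that is a limit of the assay and not a number: the limit of > 100000 nM in this assay, at which 2 of the 4 values shown sit.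

Going by these compounds, how far the true values of compound 1 and compound 4 lie past that limit stays unknown, so neither their order nor the real size of the rise from compound 2 and compound 3 can be given. On these data alone, whether an amine, a carboxylic acid or a methoxy group at this position would also reach the limit remains open.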